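From 4-cyanophenyl to 3-cyanophenyl: compound 3 and compound 4

The source may report more compounds than this note shows. Statements on the series, on what has been measured and on what is new or still open speak of the compounds shown alone.

Values measured in an ADME assay on L6 cells (Rattus norvegicus) for cytotoxicity, read by resazurin assay, with a stated time of 70 h (a higher number here means a weaker inhibitor, a lower number a stronger inhibitor), are these
Compound 1 `CC1=CC(C)(C)N(Cc2ccc(C(F)(F)F)cc2)c2ccc(OCc3ccc(C(F)(F)F)cc3)cc21` gives > 180000 nM as a limit of the assay
Compound 2 `CC(=O)Oc1ccc2c(c1)C(C)=CC(C)(C)N2Cc1ccccc1` gives 24000 nM as a number
Compound 3 `CC(=O)Oc1ccc2c(c1)C(C)=CC(C)(C)N2Cc1ccc(C#N)cc1` gives 29000 nM as a number

Compound 1 has only a limit and no number, so just two numbers can be compared. Among the compounds with values here, compound 3 gives 29000 nM in this assay and stands within the scatter of its only numbered neighbour, as the measured step of a 1.2-fold higher number from compound 2 to compound 3 (0.08 log units; within the scatter) shows.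

Compound 4 `CC(=O)Oc1ccc2c(c1)C(C)=CC(C)(C)N2Cc1cccc(C#N)c1` keeps the same atoms, joined differently. The change is 3-cyanophenyl in place of 4-cyanophenyl on a saturated chain carbon bound to a nitrogen on an aromatic ring in a ring in which 3-cyanophenyl takes the place of 4-cyanophenyl on a saturated chain carbon bound to a nitrogen on an aromatic ring in a ring.

Within the data shown here, only one measured step bears on this group, cyano in place of hydrogen on an aromatic carbon, and its size is a 1.2-fold higher number from compound 2 to compound 3 (0.08 log units; within the scatter) as measured. Among the measured compounds shown here, no measured pair compares two cyanophenyl groups. A step beyond the scatter is therefore not expected in this assay and no direction is favoured. The expected change is a 1.1-fold lower number from compound 3 to compound 4 (0.03 log units; within the scatter) by this estimate. For compound 4 the estimated value is 27000 nM with an expected range from 13000 nM to 55000 nM in this assay.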

Compound 4, half-maximal inhibitory concentration: 31000 nM
For compound 4 the middle estimate is 1.1-fold (0.06 log units) below the measured one, within the range that was stated.
By their numbers in this assay, from the lowest: compounds 2, 3 and 4 (each within the scatter of the next). At a limit, above all of these: compound 1.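

In this assay, moving the cyano group so that 3-cyanophenyl takes the place of 4-cyanophenyl on the saturated chain carbon leaves the value within the scatter, with a 1.1-fold higher number from compound 3 to compound 4 (0.03 log units; within the scatter). The earlier compounds shown here showed this only for the 4-cyanophenyl group, and the 3-cyanophenyl group now gives the same reading against the compound without a cyano group, with a 1.3-fold higher number from compound 2 to compound 4 (0.11 log units; within the scatter). At this place, then, neither the presence of the cyano group nor its placement on the ring separates these three compounds in this assay.

As far as these compounds go, whether an amine or a carboxylic acid on this ring, in place of the cyano group, would move the value beyond the scatter remains open. Nothing shown here gives a cause for these values.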